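Compound 4: swapping the hydroxy-nitrophenyl arm of compound 1

The source may hold more compounds than are shown below. What is called first, only, known or untested is meant among the compounds shown, and "the series" means these compounds.

Compound 1 `O=C(O)c1ccc(C(=O)/C(=C\c2ccc(O)c([N+](=O)[O-])c2)SCc2ccc(Br)cc2)cc1` carries a carboxy group on the aroyl ring and a bromo on the benzylthio ring. In a functional assay on DU-145 cells (Homo sapiens) for inhibition, read by trypan blue exclusion, with a stated time of 96 h (on this read-out higher numbers stand for weaker inhibition of growth and lower numbers for stronger inhibition of growth), compound 1 gives 50000 nM, the highest of the two numbers in hand; the nearest is compound 3 `O=C(/C(=C\c1ccc(O)c([N+](=O)[O-])c1)SCc1ccc(Br)cc1)c1ccc(C(F)(F)F)cc1`, which in this assay gives 10000 nM. Compound 2 `O=C(O)c1ccc(C(=O)/C(=C\c2ccc(O)c([N+](=O)[O-])c2)SCc2ccc(F)cc2)cc1` reaches only a limit of the assay, > 100000 nM in this assay, as also recorded in the limit of > 100000 nM in this assay, at which 1 of the 3 values shown sits.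

Compound 4 `O=C(O)c1ccc(C(=O)/C(=C\c2ccccc2F)SCc2ccc(Br)cc2)cc1` differs from compound 1 in one place: 2-fluorophenyl in place of 4-hydroxy-3-nitrophenyl on a double-bonded chain carbon bound to a double-bonded chain carbon. The two measured steps touch other parts of the molecule: an at least 2.0-fold higher number from compound 1 to compound 2 (0.30 log units; that floor lies within the scatter) and a 5.0-fold lower number from compound 1 to compound 3 (0.70 log units; beyond the scatter). Among the measured compounds shown here, neither varies the arm that changes here, so no measured step bears on the change from compound 1 to compound 4, and the direction is open. In the absence of a guiding step, and given that compound 1 already sits near the high end of the numbers seen, a number for compound 4 around or above that of compound 1 is expected, with a real chance that compound 4 returns only a limit in this assay. Compound 4 is estimated at 80000 nM in this assay, between 20000 nM and 200000 nM; that means an expected step of a 1.6-fold higher number from compound 1 to compound 4 (0.20 log units; within the scatter).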

Compound 4, concentration for 50% growth inhibition: 10000 nM
Compound 4: the middle estimate sits 8.0-fold (0.90 log units) above what was measured; the measured number lies below the stated range.
By their numbers in this assay, from the lowest: compounds 3 and 4 (each within the scatter of the next); then compound 1. At a limit, above all of these: compound 2.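

In this assay, the arm on a double-bonded chain carbon bound to a double-bonded chain carbon can be changed with a gain in growth inhibition: a 5.0-fold lower number from compound 1 to compound 4 (0.70 log units; beyond the scatter), with 2-fluorophenyl in place of 4-hydroxy-3-nitrophenyl. The 4-hydroxy-3-nitrophenyl arm, with its hydrogen-bond donor and acceptors, is therefore not needed for inhibition at the level of compound 1. Nothing measured here gives a reason for this step.

Among the compounds shown here, the single swap removes hydroxy and nitro and adds fluoro together, so the share of each in the step remains open. Also open, going by these compounds, are how a plain phenyl or an aminophenyl arm would read, and whether 2-fluorophenyl gives a similar step alongside trifluoromethyl in place of carboxy.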